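A few compounds are considered here, and "the series" means these few. Any claim that something is new, unique, unknown or untested is made for them only; others in the source may bear on it.

Measured so far in a functional assay on MDA-MB-231 cells (Homo sapiens) for inhibition, read by sulforhodamine B assay, with a stated time of 48 h; a lower number here means a stronger inhibitor of growth, a higher number a weaker inhibitor of growth:

compound 1 `COc1cc(C)cc(-c2c(-c3ccnc(-c4ccc(N(C)C)cc4)c3)cnn2CC#N)c1` gives 256 nM
compound 2 `COc1cc(C)cc(-c2nn(CC#N)cc2-c2ccnc(-c3ccc(N(C)C)cc3)c2)c1` gives 1090 nM
compound 3 `COc1cc(C)cc(-c2nn(CC#N)cc2-c2ccc(-c3cccc(C(C)=O)c3)nc2)c1` gives 3040 nM

Compound 2 stands second highest of these three numbers. Its nearest neighbour is compound 3, whose number is higher by a gap beyond the usual scatter; the furthest is compound 1, whose number is lower, again beyond the scatter. No two of the measured compounds differ in a single place, so no step can be read off directly within this series, and the shared core carries different substitution patterns across the three.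

Compound 4 `Cc1cc(O)cc(-c2nn(CC#N)cc2-c2ccnc(-c3ccc(N(C)C)cc3)c2)c1` has not yet been measured. Against compound 2 the change is hydrogen in place of methyl on an oxygen on an aromatic ring. Going by the values given here, nothing among the measured compounds carries this change, so the size of the step in this assay cannot be taken from the numbers already in hand; it rests on the change alone. The expectation is a small step, quite possibly within the scatter, and if anything toward a weaker inhibitor of growth. On that basis compound 4 is expected to give 1500 nM, with a range from 500 nM to 5000 nM. This estimate corresponds to an expected step of a 1.4-fold higher number from compound 2 to compound 4 (0.14 log units; within the scatter).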

Compound 4, concentration for 50% growth inhibition: 2940 nM
Compound 4: middle estimate off by 2.0-fold (0.29 log units), on the low side; the range from low to high includes it.
By their numbers in this assay, from the lowest: compound 1; then compound 2; then compounds 4 and 3 (each within the scatter of the next).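

In this assay, going by these compounds alone, the change from methoxy to hydroxy on the 3-methoxy-5-methylphenyl group gives the first single-place comparison, with a 2.7-fold higher number from compound 2 to compound 4 (0.43 log units; beyond the scatter). This shows that the group on this oxygen is not interchangeable for growth inhibition: although the step is modest, it lies beyond the scatter, and the methyl on the oxygen goes with the lower number in this pair. None of the data shown explains the step, so it remains an observation without an assigned cause.

From the compounds shown here alone, it remains open whether a step of similar size and direction would appear on the differently arranged core of compound 1 or with the different substitution of compound 3. Also open, going by these compounds, is how the series responds to a longer chain on the same oxygen, such as ethoxy or 2-aminoethoxy, or to an amine or a fluorine atom in place of the oxygen group.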